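A few compounds are considered here, and "the series" means these few. Any claim that something is new, unique, unknown or untested is made for them only; others in the source may bear on it.

Compound 1, `CNC1=CC(=O)C(C(C)(C)C)=CC1=O`: 58000 nM
Compound 2, `CCCCNC1=CC(=O)C=C(C[C@]2(C)[C@@H](C)CC[C@]3(C)C(C)=CCC[C@@H]23)C1=O`: 6000 nM

Among the compounds with values here, in a functional assay on NCI-H460 cells (Homo sapiens) for cytotoxicity, read by MTT assay, with a stated time of 72 h (on this read-out lower numbers stand for stronger inhibition and higher numbers for weaker inhibition), compound 1 gives 58000 nM, the higher of the two numbers measured so far, which makes it the weaker of the pair. Compound 2 gives 6000 nM; the gap between the two is beyond the scatter, but these two compounds differ in more than one place, so the gap cannot be tied to any single change. Compound 3, `CCCCNC1=CC(=O)C(C(C)(C)C)=CC1=O`, has not yet been measured. It differs from compound 1 by propyl in place of hydrogen on a saturated chain carbon bound to an amine nitrogen, in other words methyl to butyl, methylamino to butylamino, while the rest of the shared core is kept. Within the data shown here, no measured pair isolates this change. Compound 2 carries the same butylamino group and shows a lower number, but it also carries a different group on the core, so only a loose hint can be taken from it. A moderate step downward in this assay is therefore expected, a 2.3-fold lower number from compound 1 to compound 3 (0.37 log units; beyond the scatter), though it could also stay within the scatter. For compound 3 the expected value is 25000 nM, with a range from 8000 nM to 70000 nM.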

Compound 3, half-maximal inhibitory concentration: 72000 nM
Beside the measured number, compound 3's estimate is 2.9-fold (0.46 log units) below it; the whole stated range lies below it.
By their numbers in this assay, from the lowest: compound 2; then compounds 1 and 3 (each within the scatter of the next).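

In this assay, replacing methylamino with butylamino on the shared core gives a 1.2-fold higher number from compound 1 to compound 3 (0.09 log units; within the scatter), so compound 1 and compound 3 cannot be told apart on this read-out. Within the data shown here, this is the first comparison that isolates this position, and it shows that adding propyl in place of hydrogen on the saturated chain carbon bound to the amine nitrogen leaves the number within the usual noise of the measurement, so the butylamino group that compound 2 also carries brings no measurable gain on the core of compound 1. No available evidence offers an explanation for this result.

From the compounds shown here alone, only methyl and butyl have been compared at this position, so it remains open whether a longer chain such as octyl, a branched group such as isopropyl, or a ring-bearing group such as benzyl would move the number beyond the scatter. Going by these compounds, it also remains open whether methylamino and butylamino would match in the same way on the core of compound 2, for which a methylamino partner would be needed.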